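From Fluoro to Nitro in a Small Compound Series

The source may hold more compounds than are shown below. What is called first, only, known or untested is meant among the compounds shown, and "the series" means these compounds.

- Compound 1 `COc1cc(CCc2ccc(Cl)c(Cl)c2)cc(OC)c1O`: 13400 nM
- Compound 2 `COc1cc(CCc2ccc(F)cc2)cc(OC)c1O`: 4150 nM
- Compound 3 `COc1cc(CCc2ccccc2F)cc(OC)c1O`: > 25000 nM, a limit and not a number

These values come from a functional assay on A549 cells (Homo sapiens) for antiproliferative activity, read by MTT assay, with a stated time of 72 h; on this read-out lower numbers stand for stronger inhibition and higher numbers for weaker inhibition. Among the three compounds, compound 2 has the lowest number at 4150 nM, a clear gap from compound 1 at 13400 nM. Compound 3 gives only a limit, > 25000 nM.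

The next compound to test is compound 4 `COc1cc(CCc2ccc([N+](=O)[O-])cc2)cc(OC)c1O`. It keeps the shared core of compound 2 but has nitro in place of fluoro on an aromatic carbon, para to a large group: nitro in place of fluoro on an aromatic carbon. Within the data shown here, no measured pair in this small set shows this exchange directly, so any forecast is rough. Compound 2 at 4150 nM already has the lowest number here, so a replacement is expected to read higher rather than lower in this assay. The expected change is a small loss of inhibition, estimated as a 2.2-fold higher number from compound 2 to compound 4 (0.34 log units; beyond the scatter). The estimate for compound 4 is 9000 nM, with an expected range from 3000 nM to 25000 nM.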

Compound 4, half-maximal inhibitory concentration: 9130 nM
Estimate against measurement, compound 4: 1.0-fold (0.01 log units) below; the range from low to high includes it.
By their numbers in this assay, from the lowest: compound 2; then compounds 4 and 1 (each within the scatter of the next). At a limit, above all of these: compound 3.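

Among these compounds, the swap of fluoro for nitro, on an aromatic carbon para to a large group, gives the first direct reading of this position: in this assay there is a 2.2-fold higher number from compound 2 to compound 4 (0.34 log units; beyond the scatter), a modest step. Nitro brings three heavy atoms where fluoro had one, along with two hydrogen-bond acceptors, yet the inhibition is reduced rather than lost, so this position accepts a larger group at a modest cost, and in this pair fluoro gives the lower number. Nothing given here explains why the step has this size.

One exchange cannot show whether the loss follows from the size of the group, from its acceptors or from something else. An amine, a nitrile or a trifluoromethyl group at this same position would help to separate these possibilities, as would a plain hydrogen.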